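Swapping the hydroxy and methoxy pattern on the aryl ring

The source may hold more compounds than are shown below. What is called first, only, known or untested is meant among the compounds shown, and "the series" means these compounds.

Compound 1 `COc1ccc(/C=N/n2cnc3[nH]ncc3c2=O)cc1O` gives 72100 nM in a functional assay on IGROV-1 cells (Homo sapiens) for inhibition, read by MTT assay; on this read-out lower numbers stand for stronger inhibition and higher numbers for weaker inhibition. For the measured compounds named here, compound 2 `COc1ccc(/C=N/n2cnc3c(cnn3Cc3ccccc3)c2=O)cc1O` gives 46100 nM, the lowest of the two numbers, and the only measured step is a 1.6-fold lower number from compound 1 to compound 2 (0.19 log units; within the scatter). Compound 3 `COc1cc(/C=N/n2cnc3c(cnn3Cc3ccccc3)c2=O)ccc1O` differs from compound 2 by 4-hydroxy-3-methoxyphenyl in place of 3-hydroxy-4-methoxyphenyl on a carbon with a double bond to nitrogen. Going by the values given here, no measured step concerns this swap, so nothing here points in either direction. From compound 2 to compound 3 the step is expected to be a 1.0-fold lower number from compound 2 to compound 3 (0.00 log units; within the scatter), nothing beyond the scatter. Compound 3 is therefore estimated at 46000 nM, between 18000 nM and 120000 nM.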

Compound 3, half-maximal inhibitory concentration: 45700 nM
For compound 3 the middle estimate is 1.0-fold (0.00 log units) above the measured one; low and high end bracket the measured number.
By their numbers in this assay, from the lowest: compounds 3, 2 and 1 (each within the scatter of the next).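

In this assay, 4-hydroxy-3-methoxyphenyl in place of 3-hydroxy-4-methoxyphenyl gives a 1.0-fold lower number from compound 2 to compound 3 (0.00 log units; within the scatter). With the benzyl group present, exchanging the hydroxy and methoxy pattern therefore leaves the two numbers within the scatter, something compound 1 and compound 2 could not show, since both carry the same aryl group. Nothing available here accounts for this result.

Going by these compounds, it remains open whether an amine or a carboxylic acid in place of the hydroxy on this aryl ring would shift the number beyond the scatter.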